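Moving the aryl substituent again in a kinase-type cytotoxicity series

The source may hold more compounds than are shown below. What is called first, only, known or untested is meant among the compounds shown, and "the series" means these compounds.

Within the data shown here, compound 2 `COc1cc2c(Oc3ccc(NC(=O)c4cc(-c5ccccc5F)ccn4)cc3F)ccnc2cc1OCCCN1CCN(C)CC1` is the lower of the two numbers measured so far in a functional assay on MKN-45 cells (Homo sapiens) for cytotoxicity, read by MTT assay, with a stated time of 72 h; a lower number here means a stronger inhibitor, a higher number a weaker inhibitor. Among the measured compounds shown here, its nearest measured neighbour is compound 1 `COc1cc2c(Oc3ccc(NC(=O)c4cc(-c5ccc(F)cc5)ccn4)cc3F)ccnc2cc1OCCCN1CCN(C)CC1`, and the two differ only in the fluorophenyl group: compound 1 gives 510 nM in this assay, while compound 2 gives 150 nM, so the step of a 3.4-fold lower number from compound 1 to compound 2 (0.53 log units; beyond the scatter) is the only measured change that bears on the question at hand.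

Compound 3 `COc1cc2c(Oc3ccc(NC(=O)c4cc(-c5ccc(C(F)(F)F)cc5)ccn4)cc3F)ccnc2cc1OCCCN1CCN(C)CC1` has not yet been measured. It differs from compound 2 in one place: 4-(trifluoromethyl)phenyl in place of 2-fluorophenyl on an aromatic carbon. The change therefore returns the substituent to the position it occupied in compound 1, and at the same time exchanges fluorine for trifluoromethyl, a group for which no measured comparison exists in this set.

Because the step of a 3.4-fold lower number from compound 1 to compound 2 (0.53 log units; beyond the scatter) favoured the 2-fluorophenyl arrangement, the reverse move in compound 3 is expected to raise the number, with the trifluoromethyl group adding uncertainty in both directions. Compound 3 is thus estimated at 600 nM in this assay, with a plausible range from 200 nM to 2000 nM, corresponding to an expected step of a 4.0-fold higher number from compound 2 to compound 3 (0.60 log units; beyond the scatter).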

Compound 3, half-maximal inhibitory concentration: 330 nM
For compound 3 the middle estimate is 1.8-fold (0.26 log units) above the measured one; low and high end bracket the measured number.
By their numbers in this assay, from the lowest: compound 2; then compounds 3 and 1 (each within the scatter of the next).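

Compound 1 and compound 3 carry their substituents at the same place on the phenyl ring, so this pair isolates the exchange of fluoro for trifluoromethyl on that ring: in this assay the change gives a 1.5-fold lower number from compound 1 to compound 3 (0.19 log units; within the scatter) and the two compounds cannot be told apart, something compound 1 and compound 2 alone could not show. Compound 2 keeps the lowest number of the three, with a 2.2-fold higher number from compound 2 to compound 3 (0.34 log units; beyond the scatter) as a step beyond the scatter, although this step replaces 2-fluorophenyl with 4-(trifluoromethyl)phenyl and so alters both the substituent and where it sits on the phenyl ring. Nothing in the available data accounts for either step.

On these data alone, whether the lower number of compound 2 belongs to the 2-fluorophenyl group alone or extends to other groups remains open. As far as these compounds go, how a nitrile or an amine on the same phenyl ring would compare with fluoro and trifluoromethyl in this assay also remains open.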